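From methoxy to ethoxy on the shared core

The source may report more compounds than this note shows. Statements on the series, on what has been measured and on what is new or still open speak of the compounds shown alone.

In a functional assay (trachea) with Cavia porcellus as the target (on this read-out higher numbers stand for an effect only at larger amounts of compound and lower numbers for an effect already at smaller amounts), compound 1 (`CCCn1cnc2c1c(=O)n(C)c(=O)n2CCC`) gives 5000 nM, while compound 2 (`CCCn1c(=O)n(C)c(=O)c2c1ncn2CCOC`) gives 36100 nM, the higher of the two numbers. Compound 3 (`CCCn1c(=O)n(C)c(=O)c2c1ncn2CCOCC`) has not yet been measured. It differs from compound 2 by methyl in place of hydrogen on a saturated chain carbon bound to an oxygen on a saturated carbon, a change that also reads as methoxy to ethoxy. Among the measured compounds shown here, one measured step bears on it: a 7.2-fold higher number from compound 1 to compound 2 (0.86 log units; beyond the scatter), which is modest but beyond the scatter and came with methoxy in place of methyl. That is a different change, so it only sets a scale and does not measure this one directly. With so little to go on, no shift clearly beyond the scatter is expected, only a slight lean towards lower numbers. The expected step is a 1.6-fold lower number from compound 2 to compound 3 (0.22 log units; within the scatter). The estimate for compound 3 is 22000 nM, with an expected range from 8000 nM to 60000 nM.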

Compound 3, half-maximal effective concentration: 4600 nM
Estimate against measurement, compound 3: 4.8-fold (0.68 log units) above; the measured number lies below the stated range.
By their numbers in this assay, from the lowest: compounds 3 and 1 (each within the scatter of the next); then compound 2.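

In this assay, the position proves sensitive to a very small change: methyl in place of hydrogen on a saturated chain carbon bound to an oxygen on a saturated carbon, which reads as methoxy to ethoxy, gives a step (a 7.8-fold lower number from compound 2 to compound 3 (0.89 log units; beyond the scatter)) of about the same size as the earlier one (a 7.2-fold higher number from compound 1 to compound 2 (0.86 log units; beyond the scatter)) but in the opposite direction. An oxygen in this chain therefore does not by itself set the number, as ethoxy in place of methyl gives a step within the scatter (a 1.1-fold lower number from compound 1 to compound 3 (0.04 log units; within the scatter)). No measurement shown accounts for the size of these steps.

From the compounds shown here alone, whether a longer chain such as propoxy in place of ethoxy would hold the number or move it again stays open. So does the effect of a hydroxyl or an amine in place of ethoxy.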